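Three Methoxy Groups Instead of One on an Unchanged Framework

The compounds below may be only part of what the source reports. "The series", "measured", "known", "first", "only" and "open" are said of these compounds alone.

In a functional assay on 3T3-L1 cells (Mus musculus) for inhibition, with a stated time of 20 min, tested at 20 uM (a higher number here means more inhibition at the concentration tested (going by the name of the read-out), a lower number less inhibition), the measured compounds give the following numbers:
- compound 1 `Fc1cccc(CNCc2c[nH]c3ccccc23)c1F` gives -1.7%
- compound 2 `Cc1ccc(S(=O)(=O)N(Cc2cn(Cc3cc(F)ccc3F)nn2)Cc2cn(S(=O)(=O)c3ccccc3)c3ccccc23)cc1` gives -6.5%
- compound 3 `COc1ccc(Cn2cc(CN(Cc3cn(S(=O)(=O)c4ccc(C)cc4)c4ccccc34)S(=O)(=O)c3ccc(C)cc3)nn2)cc1` gives 1%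

Compound 3 has the highest of the three numbers, but its nearest neighbour is compound 1 and its furthest is compound 2, and both gaps lie within the usual scatter of this assay, so the three numbers count as level with one another. All three sit close to zero, which means essentially no inhibition at the concentration tested.

Compound 4 `COc1cc(OC)c(Cn2cc(CN(Cc3cn(S(=O)(=O)c4ccc(C)cc4)c4ccccc34)S(=O)(=O)c3ccc(C)cc3)nn2)c(OC)c1` keeps the whole framework of compound 3 and changes one group: 2,4,6-trimethoxyphenyl in place of 4-methoxyphenyl on a saturated chain carbon bound to an aromatic nitrogen. Among the measured compounds shown here, no pair of measured compounds differs in a single place, so there is no measured step to lean on. For the measured compounds named here, since compound 3 gives 1%, a number near zero, and the change adds only two further methoxy groups, the expected step from compound 3 to compound 4 in this assay is none beyond the scatter, no change at the digits printed from compound 3 to compound 4 (within the scatter). Compound 4 is therefore estimated at 1%, with a likely range from -9% to 11%.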

Compound 4, a percentage reported as inhibition, at one concentration (the size of the read-out at that concentration, not a potency): -22%
Compound 4: the middle estimate sits 23 percentage points above what was measured; the measured number lies below the stated range.
By their numbers in this assay, from the lowest: compound 4; then compounds 2, 1 and 3 (each within the scatter of the next).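

In this assay, replacing 4-methoxyphenyl with 2,4,6-trimethoxyphenyl on a saturated chain carbon bound to an aromatic nitrogen gives a number 23 percentage points lower from compound 3 to compound 4 (beyond the scatter) and so shows that this position can move the read-out while the rest of the framework stays the same. The change takes the number further below zero, with compound 4 at -22%, so it brings no gain in inhibition at the concentration tested. Nothing measured here accounts for this step.

The two added methoxy groups arrive together, so the step cannot be assigned to either one alone. The compounds shown also leave open how a plain phenyl, or a phenyl ring carrying an amine or a carboxylic acid, would read in this place.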